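Working notes: chloro to methoxy in the series

The source may hold more compounds than are shown below. What is called first, only, known or untested is meant among the compounds shown, and "the series" means these compounds.

Measured in a functional assay on SW-620 cells (Homo sapiens) for cytotoxicity, read by MTT assay, with a stated time of 72 h; on this read-out higher numbers stand for weaker inhibition and lower numbers for stronger inhibition:
compound 1 `COc1cccc(/C=C2\CCC/C(=C\c3ccc(Br)cc3)C2=O)c1OC` gives 11100 nM.
compound 2 `COc1cccc(/C=C2\CCC/C(=C\c3ccc(O)cc3)C2=O)c1OC` gives > 20000 nM, which is a limit.
compound 3 `COc1ccc(/C=C2\CCC/C(=C\c3cccc(Cl)c3)C2=O)cc1OC` gives 5100 nM.

Of the two true numbers, compound 3 has the lower, at 5100 nM, and compound 1 follows at 11100 nM, a gap beyond the scatter. Unmeasured compound 4 `COc1cccc(/C=C2\CCC/C(=C\c3ccc(OC)c(OC)c3)C2=O)c1` differs from compound 3 by methoxy in place of chloro on an aromatic carbon. For the measured compounds named here, the only measured step, hydroxy in place of bromo on an aromatic carbon, is an at least 1.8-fold higher number from compound 1 to compound 2 (0.25 log units; that floor lies within the scatter), a floor within the scatter and only a loose guide. A small move toward a higher number is therefore expected, the estimated step being a 1.6-fold higher number from compound 3 to compound 4 (0.20 log units; within the scatter). Compound 4 is expected at 8000 nM, with an estimated range of 3500 nM to 18000 nM.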

Compound 4, half-maximal inhibitory concentration: 3700 nM
Beside the measured number, compound 4's estimate is 2.2-fold (0.33 log units) above it, within the range that was stated.
By their numbers in this assay, from the lowest: compounds 4 and 3 (each within the scatter of the next); then compound 1. At a limit, above all of these: compound 2.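

In this assay, 3-chlorophenyl changed to 3-methoxyphenyl gives a 1.4-fold lower number from compound 3 to compound 4 (0.14 log units; within the scatter). For the compounds shown here, at this position, meta to a large group, the two groups therefore cannot be told apart on this read-out, and this is the first step to join two true numbers rather than end at a limit. Nothing available gives a cause for this step.

Going by these compounds, whether an amine or a carboxylic acid at this position would move the number beyond the scatter remains open. Also open, on these data alone, is whether methoxy and chloro stay this close with other groups on the shared core.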